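Indolyl to phenylsulfanyl at the pyrazole-adjacent carbon

This account rests on a few compounds, and the source may have more. Where it says the series, first, only, none or still open, it means among the compounds named here.

Measured compounds:
compound 1 `Cc1nn(C)c(-n2ccc3ccccc32)c1/C=N/OCc1ccc(C(=O)OC(C)(C)C)cc1`: 26.5 ug/mL
compound 2 `Cc1nn(C)c(-n2ccnc2)c1/C=N/OCc1ccc(C(=O)OC(C)(C)C)cc1`: 9.35 ug/mL

In a functional assay on SK-MEL-2 cells (Homo sapiens) for cytotoxicity (a higher number here means a weaker inhibitor, a lower number a stronger inhibitor), compound 1 gives 26.5 ug/mL, the highest of the two numbers measured; the nearest is compound 2, which gives 9.35 ug/mL. Within the data shown here, the one measured step, a 2.8-fold lower number from compound 1 to compound 2 (0.45 log units; beyond the scatter), is beyond the scatter but modest.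

Compound 3 `Cc1nn(C)c(Sc2ccccc2)c1/C=N/OCc1ccc(C(=O)OC(C)(C)C)cc1` has not been measured. It differs from compound 1 in one place: phenylsulfanyl in place of 1H-indol-1-yl on an aromatic carbon. Among the measured compounds shown here, no measured pair exchanges the indolyl for a phenylsulfanyl group, so the only step that bears on it is the exchange of the same indolyl for imidazolyl, a 2.8-fold lower number from compound 1 to compound 2 (0.45 log units; beyond the scatter), which lowered the number modestly. Going by these compounds, whether a phenylsulfanyl group behaves like imidazolyl in this assay is unknown; the step from compound 1 to compound 2 shows only that removing the indolyl did not raise the number.

Compound 3 is therefore expected to give about 18 ug/mL in this assay, with a range from 7 ug/mL to 45 ug/mL, so that the expected step of a 1.5-fold lower number from compound 1 to compound 3 (0.17 log units; within the scatter) is a small lowering that may not exceed the scatter.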

Compound 3, half-maximal inhibitory concentration: 4.91 ug/mL
The estimate for compound 3 lay 3.7-fold (0.56 log units) above the measured number, and the stated range ends above it.
By their numbers in this assay, from the lowest: compounds 3 and 2 (each within the scatter of the next); then compound 1.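

Among these compounds, the earlier step showed only that one nitrogen-linked ring could replace the 1H-indol-1-yl group with a modest gain in this assay; the phenylsulfanyl group, with 7 heavy atoms in place of 9 and a single six-membered aromatic ring in place of two fused rings, gives a larger step, a 5.4-fold lower number from compound 1 to compound 3 (0.73 log units; beyond the scatter), so this position also accepts a sulfur-bearing group that has no nitrogen. The 1H-imidazol-1-yl and phenylsulfanyl groups cannot be told apart here, with a 1.9-fold lower number from compound 2 to compound 3 (0.28 log units; within the scatter), so among the three compounds the 1H-indol-1-yl group alone stands apart from the other two. Nothing measured on these compounds accounts for the difference.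

Going by these compounds, what a phenoxy group, a plain amine or a small chlorine atom would give at this carbon stays open, and so does whether the sulfur atom itself matters or only the ring it carries. Substituents on the phenyl ring of the phenylsulfanyl group, such as a methoxy group or a fluorine atom, are also absent from the compounds shown.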